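The compounds below may be only part of what the source reports. "The series", "measured", "known", "first", "only" and "open" are said of these compounds alone.

Measured compounds:
compound 1, `c1ccc(-c2cn3ccnc3c(-c3ccc4ncn(C5CCCCC5)c4c3)n2)cc1`, 35.9%
compound 2, `COc1ccccc1-c1cn2ccnc2c(-c2ccc3ncn(C4CCCCC4)c3c2)n1`, 4.48%

Among the compounds with values here, in a functional assay on ACHN cells (Homo sapiens) for inhibition, read by sulforhodamine B assay, with a stated time of 48 h, tested at 10 uM (on this read-out lower numbers stand for less inhibition and higher numbers for more inhibition at the one concentration tested (going by the name of the read-out)), compound 2 gives the lower of the two numbers; compound 1 sits higher by a number 31.4 percentage points lower from compound 1 to compound 2 (beyond the scatter), which is the only step at hand. Compound 3, `Fc1ccccc1-c1cn2ccnc2c(-c2ccc3ncn(C4CCCCC4)c3c2)n1`, differs from compound 2 by fluoro in place of methoxy on an aromatic carbon. Within the data shown here, no measured step tells what exchanging methoxy for fluoro does here, so compound 3 is expected to land between its two neighbours, a step of a number 15.5 percentage points higher from compound 2 to compound 3 (beyond the scatter) from compound 2. The estimate for compound 3 in this assay is 20%, with a range from 0% to 45%.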

Compound 3, a percentage reported as inhibition, at one concentration (the size of the read-out at that concentration, not a potency): 13.2%
Beside the measured number, compound 3's estimate is 6.8 percentage points above it; low and high end bracket the measured number.
By their numbers in this assay, from the lowest: compounds 2 and 3 (each within the scatter of the next); then compound 1.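

In this assay, the step of a number 8.7 percentage points higher from compound 2 to compound 3 (within the scatter) leaves 2-methoxyphenyl and 2-fluorophenyl indistinguishable at this position. The step of a number 22.7 percentage points lower from compound 1 to compound 3 (beyond the scatter) shows that the lower number is not confined to methoxy, since fluoro on the same aromatic carbon, ortho to a large group, also gives less inhibition than hydrogen. Nothing available explains why these groups differ from hydrogen. On these data alone, whether an amine or a carboxylic acid on this aromatic carbon would stay near compound 1 or fall with the other two remains open.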